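Chloro for Bromo: an Expectation for Compound 4

A few compounds are considered here, and "the series" means these few. Any claim that something is new, unique, unknown or untested is made for them only; others in the source may bear on it.

Compound 1 `O=C1NC(=S)/C(=C/c2ccc(Cl)cc2)S1`: 3.91%
Compound 2 `O=C1NC(=S)/C(=C/c2ccccc2Br)S1`: 10.3%
Compound 3 `O=C1NC(=S)/C(=C/c2ccc(Br)cc2)S1`: -0.36%

Of the compounds shown here, three have been tested in a functional assay on HEp-2 cells (Homo sapiens) for cytotoxicity, read by MTT assay, with a stated time of 72 h, tested at 2.5 ug/mL; on this read-out higher numbers stand for more inhibition of growth at the one concentration tested and lower numbers for less inhibition of growth. In this assay compound 3 gives -0.36% and compound 1 gives 3.91%; the step of a number 4.3 percentage points higher from compound 3 to compound 1 (within the scatter) belongs to the change (chloro in place of bromo on an aromatic carbon). Compound 2 gives 10.3%; the difference between the core of compound 2 and the core of compound 3 is not broken down here, beyond the fact that the two share the same atoms joined differently.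

Compound 4 `O=C1NC(=S)/C(=C/c2ccccc2Cl)S1` has not yet been measured. It differs from compound 2 by chloro in place of bromo on an aromatic carbon. This is the same kind of change as that from compound 3 to compound 1, but the place is not the same: there the chloro sits para to a group of 8 heavy atoms, here ortho to a group of 8 heavy atoms. Among the measured compounds shown here, the only precedent is the step of a number 4.3 percentage points higher from compound 3 to compound 1 (within the scatter), which lies within the scatter, so the expected step from compound 2 to compound 4 in this assay is a number 2.7 percentage points higher from compound 2 to compound 4 (within the scatter). Compound 4 is therefore estimated at 13%, between 2% and 24%.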

Compound 4, percent growth inhibition at one concentration: -11.5%
Compound 4: the middle estimate sits 24.5 percentage points above what was measured; the whole stated range lies above it.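

In this assay, putting chloro in place of bromo on an aromatic carbon, ortho to a group of 8 heavy atoms, gives a number 21.8 percentage points lower from compound 2 to compound 4 (beyond the scatter), so this change has a different outcome here than in the earlier pair. The two outcomes do not agree, and in this series the result of the change cannot be carried from one core to the other: the same change on two cores in this assay, a number 4.3 percentage points higher (within the scatter) from compound 3 to compound 1 and a number 21.8 percentage points lower (beyond the scatter) from compound 2 to compound 4, 26.1 percentage points apart, beyond the scatter of two such steps.

This does not show why the two steps part, since the halogen also stands at a different place on the ring in the two pairs, and two pairs of compounds, each tested at one concentration, give no general rule for the change.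

The compounds shown carry only halogens on the aromatic ring, so they leave open how an amine, a carboxylic acid or a methoxy group would behave at the same place. They also leave open whether fluoro in place of bromo would follow either step.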